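The source may hold more compounds than are shown below. What is called first, only, known or untested is meant among the compounds shown, and "the series" means these compounds.

Three compounds of the series have numbers in a functional assay on HCT-15 cells (Homo sapiens) for cytotoxicity, read by CCK-8 assay and cell counting, with a stated time of 2 days; on this read-out higher numbers stand for weaker inhibition and lower numbers for stronger inhibition. Compound 1 `Oc1ccc(-c2cc(-c3ccccc3)nc(-c3ccccc3Cl)c2)cc1` gives 4990 nM and stands highest of the three, but its nearest neighbour compound 3 `Oc1cccc(-c2cc(-c3ccccc3)nc(-c3ccccc3Cl)c2)c1` gives 2930 nM, and the furthest, compound 2 `Oc1cccc(-c2cc(-c3cccc(Cl)c3)nc(-c3cccs3)c2)c1`, gives 2610 nM; both gaps are within the scatter, so no ordering among the three can be read. Going by the values given here, the one single-point step that is available, a 1.7-fold lower number from compound 1 to compound 3 (0.23 log units; within the scatter), moves a hydroxyphenyl group and does not touch the position changed here.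

Compound 4 `Oc1ccc(-c2cc(-c3ccsc3)nc(-c3ccccc3Cl)c2)cc1` differs from compound 1 as follows: thiophen-3-yl in place of phenyl on an aromatic carbon, on the carbon next to the ring nitrogen. Among the compounds with values here, no measured pair isolates this exchange; compound 2 carries a thiophene ring elsewhere on the core but differs from compound 1 in more than one place, so only its value above can be set beside compound 1, and that value lies within the scatter of compound 1. On this basis compound 4 is expected to show a 1.1-fold lower number from compound 1 to compound 4 (0.04 log units; within the scatter), that is, no step beyond the scatter in this assay. The estimate for compound 4 in this assay is 4500 nM, with a range of 2000 nM to 10000 nM.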

Compound 4, half-maximal inhibitory concentration: 5830 nM
For compound 4 the middle estimate is 1.3-fold (0.11 log units) below the measured one, and the stated range covers the measured number.
By their numbers in this assay, from the lowest: compounds 2, 3, 1 and 4 (each within the scatter of the next, the first and the last beyond it).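

In this assay thiophen-3-yl in place of phenyl on the aromatic carbon next to the ring nitrogen gives a 1.2-fold higher number from compound 1 to compound 4 (0.07 log units; within the scatter) as its step. Going by these compounds alone, this is the first pair to isolate an exchange at this position, and it shows that a five-membered aromatic ring with sulfur can replace the six-membered carbon ring here with no step beyond the scatter. No measurement at hand offers an explanation for this result.

At this position the compounds shown carry only aromatic rings, so the effect of an amine, a carboxylic acid or a longer chain there remains open. On these data alone, whether the same exchange would give a step of like size on the core of compound 3 also remains open.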